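Bromo analogue with cyclohexyl in place of isobutyl

This account rests on a few compounds, and the source may have more. Where it says the series, first, only, none or still open, it means among the compounds named here.

For the measured compounds named here, in a functional assay on SW1573 cells (Homo sapiens) for antiproliferative activity, read by sulforhodamine B assay, with a stated time of 48 h (a lower number here means a stronger inhibitor of growth, a higher number a weaker inhibitor of growth), compound 2 `Cc1ccc(S(=O)(=O)N2CC[C@@H](Br)C[C@@H]2CC(C)C)cc1` gives 22000 nM, the lowest of the two numbers known, with compound 1 `Cc1ccc(S(=O)(=O)N2CC[C@@H](Cl)C[C@@H]2C2CCCCC2)cc1` giving 53000 nM in this assay. Compound 3 `Cc1ccc(S(=O)(=O)N2CC[C@@H](Br)C[C@@H]2C2CCCCC2)cc1` differs from compound 2 by cyclohexyl in place of isobutyl on a saturated ring carbon. Going by the values given here, no measured pair shows this change on its own; compound 1, which also carries cyclohexyl beside a chloro group, gives the higher number of the two, so compound 3 is expected to land at a modestly higher number, with a step of a 1.7-fold higher number from compound 2 to compound 3 (0.24 log units; within the scatter). Compound 3 is therefore estimated at 38000 nM, within 13000 nM to 100000 nM.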

Compound 3, concentration for 50% growth inhibition: 82000 nM
The estimate for compound 3 lay 2.2-fold (0.33 log units) below the measured number; the range from low to high includes it.
By their numbers in this assay, from the lowest: compound 2; then compounds 1 and 3 (each within the scatter of the next).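

In this assay, cyclohexyl in place of isobutyl on this saturated ring carbon gives a 3.7-fold higher number from compound 2 to compound 3 (0.57 log units; beyond the scatter), so this position responds to the change when it stands alone. Bromo in place of chloro gives a 1.5-fold higher number from compound 1 to compound 3 (0.19 log units; within the scatter), so the two halogens cannot be told apart when cyclohexyl is present. Nothing measured bears on the reason for either step.

The compounds shown leave open whether a phenyl ring or a methyl group at this carbon would read nearer compound 2 or compound 3. They also leave open how an amine in place of the bromo group would read with isobutyl present.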